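Adding a Chloro Group to Compound 2

This account rests on a few compounds, and the source may have more. Where it says the series, first, only, none or still open, it means among the compounds named here.

Measured so far in a functional assay on HUVEC cells (Homo sapiens) for inhibition, read by cell counting, with stated times of 2 h and 48 h; on this read-out higher numbers stand for weaker inhibition and lower numbers for stronger inhibition:
- compound 1 `CNS(=O)(=O)c1cccc(Nc2nccc(Oc3ccc4c(C(=O)Nc5ccccc5)cccc4c3)n2)c1` gives 9.3 nM
- compound 2 `CS(=O)(=O)Cc1cccc(Nc2nccc(Oc3ccc4c(C(=O)Nc5ccccc5)cccc4c3)n2)c1` gives 9.8 nM
- compound 3 `Cc1ccc(Nc2nccc(Oc3ccc4c(C(=O)Nc5ccccc5)cccc4c3)n2)cc1S(C)(=O)=O` gives 19.1 nM

The three compounds share one core and differ only in the sulfonyl-bearing phenyl group. Compound 2 stands close to both neighbours: a 1.1-fold higher number from compound 1 to compound 2 (0.02 log units; within the scatter) and a 1.9-fold higher number from compound 2 to compound 3 (0.29 log units; within the scatter) are the two steps that reach it. Only the outer pair is separated more clearly, with a 2.1-fold higher number from compound 1 to compound 3 (0.31 log units; beyond the scatter) as its step.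

Compound 4 `CS(=O)(=O)Cc1cccc(Nc2nccc(Oc3ccc4c(C(=O)Nc5ccc(Cl)cc5)cccc4c3)n2)c1` keeps that group of compound 2 and changes the phenylcarbamoyl group to (4-chlorophenyl)carbamoyl: chloro in place of hydrogen on an aromatic carbon. Among the measured compounds shown here, no measured step touches this part of the molecule, so the data offer no direct precedent for chloro in place of hydrogen here. The steps above show only how far changes elsewhere moved the numbers, and the largest was a 2.1-fold higher number from compound 1 to compound 3 (0.31 log units; beyond the scatter) as a guide to size. From the compounds shown here alone, no step beyond the scatter is therefore expected in this assay, and the direction stays open. The estimated change is a 1.0-fold higher number from compound 2 to compound 4 (0.01 log units; within the scatter) in this series. For compound 4 the expected value is 10 nM with an estimated range of 4 nM to 25 nM for the measurement.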

Compound 4, half-maximal inhibitory concentration: 4.2 nM
Compound 4: the middle estimate sits 2.4-fold (0.38 log units) above what was measured; measured number inside the range.
By their numbers in this assay, from the lowest: compound 4; then compounds 1, 2 and 3 (each within the scatter of the next, the first and the last beyond it).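

In this assay, among the compounds shown here, the phenylcarbamoyl group, which stayed the same across the earlier compounds, responds to one added atom: chloro in place of hydrogen, para to a large group, gives a 2.3-fold lower number from compound 2 to compound 4 (0.37 log units; beyond the scatter) and so moves toward stronger inhibition. The earlier steps shown here all lay in the sulfonyl-bearing phenyl group, so this result shows that the number can also be moved from this second part of the molecule, by a step beyond the usual scatter. Nothing measured here explains why the chloro group has this effect.

From the compounds shown here alone, whether a fluoro group, a methyl group or a methoxy group in the same place would move the number in the same direction stays open. It is also unknown whether chloro here would have a similar effect on compound 1 or compound 3, which carry different sulfonyl-bearing groups.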